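Dibromophenyl to fluoronitrophenyl on the vinyl carbon

The source may hold more compounds than are shown below. What is called first, only, known or untested is meant among the compounds shown, and "the series" means these compounds.

Two compounds carry the shared core so far. Compound 1 `Nc1c(Br)cc(Br)cc1/C=C(\C(=O)c1ccc(Br)cc1)S(=O)(=O)c1ccc(Br)cc1` is one of them, and in a functional assay on DU-145 cells (Homo sapiens) for inhibition, read by trypan blue exclusion, with a stated time of 96 h (a lower number here means a stronger inhibitor of growth, a higher number a weaker inhibitor of growth), compound 1 gives 25000 nM. Compound 2 `COc1ccsc1/C=C(\C(=O)c1ccc(Br)cc1)S(=O)(=O)Cc1ccc(Cl)cc1` is the other, and in this assay compound 2 gives 50000 nM. The two numbers lie within the scatter of each other, so neither compound can be set apart from the other on these data; both sit at the weak end of what this read-out covers.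

Compound 3 `O=C(/C(=C\c1ccc(F)c([N+](=O)[O-])c1)S(=O)(=O)c1ccc(Br)cc1)c1ccc(Br)cc1` has not been measured. Its change from compound 1 is 4-fluoro-3-nitrophenyl in place of 2-amino-3,5-dibromophenyl on a double-bonded chain carbon bound to a double-bonded chain carbon. Going by the values given here, no pair of measured compounds differs in one place, so no measured step on the core is available to lean on, and the size of this step can only be judged from the two weak numbers in hand.

Compound 3 is expected to stay close to compound 1, with a 1.2-fold higher number from compound 1 to compound 3 (0.08 log units; within the scatter) as the estimated step, no larger than the scatter in either direction. For compound 3 the estimate in this assay is 30000 nM, with a range from 9000 nM to 100000 nM.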

Compound 3, concentration for 50% growth inhibition: 25000 nM
Compound 3: the middle estimate sits 1.2-fold (0.08 log units) above what was measured; the measured number falls inside the stated range.
By their numbers in this assay, from the lowest: compounds 1, 3 and 2 (each within the scatter of the next).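

In this assay, going by these compounds alone, 4-fluoro-3-nitrophenyl in place of 2-amino-3,5-dibromophenyl on a double-bonded chain carbon bound to a double-bonded chain carbon gives no change at the digits printed from compound 1 to compound 3 (within the scatter), the only step on the shared core that can be read so far. This position therefore accepts an exchange of substituents on the six-membered aromatic ring with no change beyond the scatter: the group that leaves has 2 bromine atoms and 1 hydrogen-bond donor, while the group that enters has 1 fluorine atom and 0 hydrogen-bond donors. Nothing measured here explains why the number holds across this exchange.

Because all the ring substituents change in this one step, the separate contributions of the amino, bromo, fluoro and nitro groups remain unresolved. As far as these compounds go, it also remains open whether a different group in this place, such as an unsubstituted phenyl, a pyridine or a phenol, would move the number in this assay beyond the scatter, or whether every group here would stay within it.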